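From Pyrazin-2-yl to 1,2-Thiazol-5-yl: an Estimate

This account rests on a few compounds, and the source may have more. Where it says the series, first, only, none or still open, it means among the compounds named here.

The study covers two measured compounds and one not yet measured. Compound 1 `Cc1cccnc1-c1ccccc1OCC1=NCCN1` was examined in a functional assay for activation of Alpha-1D adrenergic receptor (Homo sapiens), read by calcium flux; on this read-out higher numbers stand for an effect only at larger amounts of compound and lower numbers for an effect already at smaller amounts. In this assay compound 1 gives < 100000 nM, which is a limit of the assay rather than a number. Compound 2 `c1ccc(-c2cnccn2)c(OCC2=NCCN2)c1` is the closer relative of the new compound. In this assay compound 2 gives < 100000 nM, again a limit of the assay and not a number. The shared position of both is the limit of < 100000 nM in this assay, at which 2 of the 2 values shown sit, so no order between compound 1 and compound 2 can be read from the numbers shown. Compound 3 `c1ccc(-c2ccns2)c(OCC2=NCCN2)c1` differs from compound 2 in one place: 1,2-thiazol-5-yl in place of pyrazin-2-yl on an aromatic carbon. Among the compounds with values here, no measured step accompanies this change, and the writer expects only a small step, if any, a step that the limit leaves unreadable from compound 2 to compound 3. Compound 3 is estimated at 60000 nM, within a range from 10000 nM to 200000 nM, most likely reported once more only as a limit.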

Compound 3, half-maximal effective concentration: 25.1 nM
The estimate for compound 3 lay 2400-fold (3.38 log units) above the measured number, outside the stated range (below it).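

No step from compound 2 to compound 3 can be read in this assay, because the value of compound 2 is a limit of the assay and not a number: the limit of < 100000 nM in this assay, at which 2 of the 3 values shown sit.

The compounds shown leave open how large the effect of replacing pyrazin-2-yl with 1,2-thiazol-5-yl is.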